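Aminophenyl amidine series: trifluoromethyl on the amidine phenyl

This account rests on a few compounds, and the source may have more. Where it says the series, first, only, none or still open, it means among the compounds named here.

Of the compounds shown here, two have numbers so far in an assay for inhibition of Nitric oxide synthase, inducible (Homo sapiens), read by ELISA, with a stated time of 30 min; on this read-out lower numbers stand for stronger inhibition and higher numbers for weaker inhibition. Compound 1 `CCNC(=O)NCCC(=O)c1cc(Cl)ccc1N` gives 100000 nM in this assay. Compound 2 `COc1ccc(N)c(C(O)CCNC(=N)c2ccccc2)c1` gives 22500 nM in this assay. Compound 2 therefore stands at the lowest of the two numbers; its nearest neighbour is compound 1, whose number is higher by a margin that lies beyond the scatter. Within the data shown here, no pair among the measured compounds differs in a single place, so no measured step is available to lean on.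

Compound 3 `COc1ccc(N)c(C(O)CCNC(=N)c2ccc(C(F)(F)F)cc2)c1` is not yet measured in this assay. It differs from compound 2 by a single change: trifluoromethyl in place of hydrogen on an aromatic carbon. Among the measured compounds shown here, nothing among the measured compounds tells how this assay responds to such a change on this ring, so no step beyond the scatter is expected in either direction. The number for compound 3 in this assay is estimated at 20000 nM, within a range of 5000 nM to 80000 nM. The step that this estimate means, a 1.1-fold lower number from compound 2 to compound 3 (0.05 log units; within the scatter), is expected to stay within the scatter.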

Compound 3, half-maximal inhibitory concentration: 20000 nM
Compound 3: middle estimate and measured number agree at the digits printed; low and high end bracket the measured number.
By their numbers in this assay, from the lowest: compounds 3 and 2 (each within the scatter of the next); then compound 1.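

Trifluoromethyl in place of hydrogen on an aromatic carbon, para to a large group, gives a 1.1-fold lower number from compound 2 to compound 3 (0.05 log units; within the scatter) in this assay. Among these compounds, this is the first measured step, and it shows that this place carries a group of 4 heavy atoms with compound 3 remaining within the scatter of compound 2. No measurement bearing on this result accompanies the compounds, and the finding therefore stands as a bare observation on one pair.

A single step marks out only these two groups at this one place, and it does not show whether the read-out is insensitive to substitution here in general; an amine, a carboxylic acid or a longer alkyl chain at the same aromatic carbon would test that. Also open, as far as these compounds go, is whether trifluoromethyl on another carbon of the same ring reads the same in this assay, and whether the same step holds when the rest of the core of compound 2 differs.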